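The source may report more compounds than this note shows. Statements on the series, on what has been measured and on what is new or still open speak of the compounds shown alone.

Measured so far:
compound 1 `COc1ccc(Cl)cc1C(=O)NCCC1CCN(S(=O)(=O)NC(=O)NC[C@@H]2C[C@@H]3CC[C@@H]2O3)CC1` — 30%
compound 2 `COc1ncccc1C(=O)NCCC1CCN(S(=O)(=O)NC(=O)NC[C@@H]2C[C@@H]3CC[C@@H]2O3)CC1` — 34%

In a functional assay on the whole organism (blood) with Rattus norvegicus as the target, with stated times of 24 h and 1 h, at a dose of 5 mg/kg by the intraperitoneal route (a lower number here means a weaker effect, a higher number a stronger effect of the compound at the dose given), compound 1 gives 30%, and in this assay compound 2 gives 34%. Compound 2 holds the higher of the two numbers, but only by a number 4 percentage points higher from compound 1 to compound 2 (within the scatter), so the two values are not separated. That step exchanged the group on the carbonyl carbon and left the rest of the core untouched.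

Compound 3 `CCOCCNC(=O)NS(=O)(=O)N1CCC(CCNC(=O)c2cccnc2OC)CC1` keeps the group on the carbonyl carbon of compound 2 and changes the other end: a group of 4 heavy atoms (3 carbon, 1 oxygen; no ring) in place of a group of 7 heavy atoms (6 carbon, 1 oxygen; 2 five-membered non-aromatic rings with 1 hetero atom each), on a saturated chain carbon bound to an amide-type nitrogen. Going by the values given here, no measured step touches this part of the molecule, so the one step known, a number 4 percentage points higher from compound 1 to compound 2 (within the scatter), gives no guide to the size or direction of the change here. The expectation for compound 3 therefore rests on the narrow spread of the two numbers seen, with a wide range. The step from compound 2 is expected to be small, a number 4 percentage points lower from compound 2 to compound 3 (within the scatter). Compound 3 is estimated at 30% in this assay, with a range from 10% to 50%.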

Compound 3, a percentage reported as activity, at one dose (the size of the read-out at that dose, not a potency): 7%
Compound 3: the middle estimate sits 23 percentage points above what was measured, outside the stated range (below it).
By their numbers in this assay, from the lowest: compound 3; then compounds 1 and 2 (each within the scatter of the next).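

In this assay this end of the molecule, on a saturated chain carbon bound to an amide-type nitrogen, proves responsive where the exchange on the carbonyl carbon did not: ethoxymethyl in place of the group of 7 heavy atoms gives a number 27 percentage points lower from compound 2 to compound 3 (beyond the scatter). The two groups have the same counts of hydrogen-bond donors and acceptors and neither carries a net charge; they differ in heavy atoms, in the 2 five-membered non-aromatic rings and in the 3 defined stereocentres. No measurement on hand explains the step.

With a single replacement shown at this position, it remains open whether the rings, the stereocentres or the size of the group go with the higher value. A cyclohexyl group or a longer alkyl chain without oxygen at the same place would help separate these readings.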